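Compound 1 to compound 3: losing the imidazolyl chain

This account rests on a few compounds, and the source may have more. Where it says the series, first, only, none or still open, it means among the compounds named here.

compound 1 `O=C(NCCCn1ccnc1)Nc1n[nH]c2cc(Cl)c(-c3ccccc3)cc12`: < 20000 ug/mL
compound 2 `CN1CCN(CCCNC(=O)Nc2n[nH]c3cc(Cl)c(-c4ccccc4)cc23)CC1`: > 208000 ug/mL

In a physicochemical assay for solubility (a lower number here means a less soluble compound, a higher number a more soluble compound), compound 1 gives < 20000 ug/mL, which is a limit and not a number. Compound 2 gives > 208000 ug/mL, which is also a limit. Compound 1 therefore sits at the low end of the two measured compounds, with its exact value unknown.

The next compound is compound 3 `O=C(Nc1n[nH]c2cc(Cl)c(-c3ccccc3)cc12)N1CCCC1`, and the change is pyrrolidin-1-yl in place of (3-(1H-imidazol-1-yl)propyl)amino on a carbonyl carbon.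

Within the data shown here, one measured step bears on this: an at least 10-fold higher number from compound 1 to compound 2 (1.01 log units; beyond the scatter), which is large and beyond the scatter. That step replaced the 1H-imidazol-1-yl group with 4-methylpiperazin-1-yl and kept the chain, whereas compound 3 loses both the group and the chain. Among the measured compounds shown here, it is therefore only a loose guide, and no measured compound carries pyrrolidin-1-yl. The higher number belongs to compound 2, which keeps the chain, so a move to a lower number is expected, smaller than the measured step. The expected step runs a step that the limit leaves unreadable from compound 1 to compound 3. The estimate for compound 3 is 6000 ug/mL, with an expected range of 800 ug/mL to 30000 ug/mL.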

Compound 3, solubility: < 20000 ug/mL
Compound 3: a limit, no number; the forecaster's own chance of this, stated with the estimate: 55%; the middle value is on the limit's open side.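

In this assay compound 3 gives < 20000 ug/mL, which is a limit and not a number. Among these compounds, compound 1 also stands at a limit, so no step from compound 1 to compound 3 can be read. The compounds shown leave open where either compound truly lies, and whether pyrrolidin-1-yl in place of (3-(1H-imidazol-1-yl)propyl)amino on a carbonyl carbon changes the read-out at all.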